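Adding One Methyl to the Isopropyl Group

The source may hold more compounds than are shown below. What is called first, only, known or untested is meant among the compounds shown, and "the series" means these compounds.

In a functional assay on A549 cells (Homo sapiens) for cytotoxicity, with a stated time of 48 h (a higher number here means a weaker inhibitor, a lower number a stronger inhibitor), compound 1 `C[S+]([O-])/C=C/c1cc(=O)c2cc(F)ccc2o1` gives 2100 nM and compound 2 `CC(C)C(=O)Oc1ccc2oc(/C=C/[S+](C)[O-])cc(=O)c2c1` gives 2400 nM as its reading. Compound 2 therefore stands level with compound 1 within the scatter, and no order can be drawn between them.

Compound 3 `C[S+]([O-])/C=C/c1cc(=O)c2cc(OC(=O)C(C)(C)C)ccc2o1` has not yet been measured in this assay and departs from compound 2 by a single change: methyl in place of hydrogen on a saturated chain carbon bound to a carbonyl carbon and two saturated chain carbons in the side chain. This is methyl in place of hydrogen on a saturated chain carbon bound to a carbonyl carbon and two saturated chain carbons, so that isopropyl becomes tert-butyl.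

For the measured compounds named here, only one measured step bears on this change, and only indirectly. Putting (isopropylcarbonyl)oxy in place of fluoro on an aromatic carbon gave a 1.1-fold higher number from compound 1 to compound 2 (0.06 log units; within the scatter) as the entire shift. Going by the values given here, with so small a step as the only guide, no movement beyond the scatter is expected in either direction. The expected step is no change at the digits printed from compound 2 to compound 3 (within the scatter) on this estimate. Compound 3 is estimated at 2400 nM with an expected range from 1100 nM to 5000 nM in this cell test.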

Compound 3, half-maximal inhibitory concentration: 1600 nM
The estimate for compound 3 lay 1.5-fold (0.18 log units) above the measured number; the range from low to high includes it.
By their numbers in this assay, from the lowest: compounds 3, 1 and 2 (each within the scatter of the next).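

The added methyl that turns isopropyl into tert-butyl gave a 1.5-fold lower number from compound 2 to compound 3 (0.18 log units; within the scatter) in this assay and so leaves the reading level: the saturated chain carbon bound to a carbonyl carbon and two saturated chain carbons takes one more methyl without a shift that can be told from the scatter. Placing ((tert-butyl)carbonyl)oxy on the aromatic carbon in place of fluoro gave a 1.3-fold lower number from compound 1 to compound 3 (0.12 log units; within the scatter) as the whole difference, so fluoro, (isopropylcarbonyl)oxy and ((tert-butyl)carbonyl)oxy now all stand level at this place, and neither the larger side chain nor the smaller atom separates itself in this cell test. No supporting measurement accompanies these readings, so they remain a plain record of numbers with nothing to explain them.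

As far as these compounds go, whether a group of another kind at this place, such as an amine or a carboxylic acid, would move the number beyond the scatter remains open. So does the effect of a longer chain in place of tert-butyl, and all three compounds share one core, so they say nothing about changes made elsewhere on it.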